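The source may hold more compounds than are shown below. What is called first, only, known or untested is meant among the compounds shown, and "the series" means these compounds.

Compound 2, `COc1cc2nc(N3CCC(OCCOc4ccccc4)CC3)nc(N)c2cc1OC`, is the reference point here. In an assay on brain for displacement of a labelled ligand from Adrenergic receptor alpha-1 (Rattus norvegicus) (a higher number here means a weaker inhibitor, a lower number a stronger inhibitor), compound 2 gives 0.48 nM, the lowest number among the three measured compounds. Compound 1, `COCCOC1CCN(c2nc(N)c3cc(OC)c(OC)cc3n2)CC1`, gives 2.12 nM in this assay, and compound 3, `COc1cc2nc(N3CCC(OCC(C)(C)OC)CC3)nc(N)c2cc1OC`, gives 1.14 nM. The steps of a 4.4-fold lower number from compound 1 to compound 2 (0.65 log units; beyond the scatter) and a 2.4-fold higher number from compound 2 to compound 3 (0.38 log units; beyond the scatter) both lie beyond the scatter, so compound 2 stands as the strongest inhibitor of the three, while a 1.9-fold lower number from compound 1 to compound 3 (0.27 log units; within the scatter) is within the scatter.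

Compound 4, `COc1cc2nc(N3CCC(OCC(C)O)CC3)nc(N)c2cc1OC`, differs from compound 2 by 1-hydroxyethyl in place of phenoxymethyl on a saturated chain carbon bound to an oxygen on a saturated carbon. The step that bears on it most directly is a 4.4-fold lower number from compound 1 to compound 2 (0.65 log units; beyond the scatter), where the phenyl on the oxygen lowered the number; compound 4 removes that phenyl entirely and also removes the outer oxygen's methyl, leaving a hydroxyl. The step of a 2.4-fold higher number from compound 2 to compound 3 (0.38 log units; beyond the scatter) shows that trading the phenoxymethyl for a small alkoxy group costs a modest amount. Compound 4 is therefore expected to lose roughly what compound 2 gained, with a 5.2-fold higher number from compound 2 to compound 4 (0.72 log units; beyond the scatter) as the expected step. For compound 4 the estimate in this assay is 2.5 nM, in a range from 0.9 nM to 7 nM.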

Compound 4, inhibition constant: 3.52 nM
Estimate against measurement, compound 4: 1.4-fold (0.15 log units) below; the range from low to high includes it.
By their numbers in this assay, from the lowest: compound 2; then compounds 3, 1 and 4 (each within the scatter of the next, the first and the last beyond it).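

In this assay the change from phenoxymethyl to 1-hydroxyethyl, on a saturated chain carbon bound to an oxygen on a saturated carbon, gives a 7.3-fold higher number from compound 2 to compound 4 (0.87 log units; beyond the scatter) and leaves compound 2, the only one with a phenyl, clear of all three others. Set against 1-methoxy-1-methylethyl, the 1-hydroxyethyl group gives a 3.1-fold higher number from compound 3 to compound 4 (0.49 log units; beyond the scatter) while set against methoxymethyl it gives a 1.7-fold higher number from compound 1 to compound 4 (0.22 log units; within the scatter) so the three groups without a ring overlap rather than fall into separate levels. Compound 4 brings the first hydrogen-bond donor to this place, yet it is not set apart from compound 1.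

Nothing given here accounts for these differences. The compounds shown leave open whether the low number of compound 2 depends on the phenyl ring itself, or whether a longer chain or a terminal amine would serve as well.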